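The source may report more compounds than this note shows. Statements on the series, on what has been measured and on what is new or still open speak of the compounds shown alone.

Measured in an ADME assay on MDCK cells (Canis lupus familiaris) for cytotoxicity; on this read-out lower numbers stand for higher toxicity in this test and higher numbers for lower toxicity in this test:
- compound 1 `Cn1ccnc1Sc1cnc(-c2ccc(Cl)cc2)nc1-c1ccccc1O` gives 80100 ug/mL
- compound 2 `Cn1ccnc1Sc1cnc(-c2ccncc2)nc1-c1ccccc1O` gives 64700 ug/mL
- compound 3 `Cn1ccnc1Sc1cnc(C(C)(C)C)nc1-c1ccccc1O` gives 194000 ug/mL

Compound 3 stands highest of these three numbers in this assay: its nearest neighbour is compound 1, reached by a 2.4-fold higher number from compound 1 to compound 3 (0.38 log units; beyond the scatter), and the furthest is compound 2, reached by a 3.0-fold higher number from compound 2 to compound 3 (0.48 log units; beyond the scatter). Compound 4 `Cn1ccnc1Sc1cnc(N)nc1-c1ccccc1O` follows from compound 3 by one change, (amino in place of tert-butyl on an aromatic carbon). Both measured steps at this same position, from an aryl group to tert-butyl, raised the number by a modest amount; neither tells how an amino group behaves here. The step from tert-butyl to amino is therefore expected to fall somewhere between no change and a modest return toward the numbers of compound 1 and compound 2, so a 1.5-fold lower number from compound 3 to compound 4 (0.17 log units; within the scatter) is the estimated step. Compound 4 is expected to give about 130000 ug/mL in this assay, within a range from 60000 ug/mL to 280000 ug/mL.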

Compound 4, half-maximal cytotoxic concentration: 388000 ug/mL
For compound 4 the middle estimate is 3.0-fold (0.47 log units) below the measured one, and the stated range ends below it.
By their numbers in this assay, from the lowest: compounds 2 and 1 (each within the scatter of the next); then compounds 3 and 4 (each within the scatter of the next).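

In this assay, amino and tert-butyl at this position between two ring nitrogen atoms cannot be told apart: the result is a 2.0-fold higher number from compound 3 to compound 4 (0.30 log units; within the scatter). Against the aryl groups, amino gives a 6.0-fold higher number from compound 2 to compound 4 (0.78 log units; beyond the scatter) and a 4.8-fold higher number from compound 1 to compound 4 (0.69 log units; beyond the scatter), so tert-butyl is no longer the only group without a ring that stands clear of both aryl compounds. No evidence here explains these differences. From the compounds shown here alone, it remains open whether a methylamino group, a dimethylamino group or a simple methyl group would keep the number at the level of compound 3 and compound 4.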